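This account rests on a few compounds, and the source may have more. Where it says the series, first, only, none or still open, it means among the compounds named here.

Working notes on the series. Compound 1 `CNc1nnc(Cn2c(=O)oc3ccc(C)cc32)s1`, compound 2 `CCNc1nnc(Cn2c(=O)oc3ccc(C)cc32)s1` and compound 3 `CCCNC(=S)NNC(=O)Cn1c(=O)oc2ccc(C)cc21` have been run in a functional assay on the whole organism for inhibition, with Mus musculus as the target, read by paw edema, with a stated time of 180 min, at a dose of 100 mg/kg by the oral route; a higher number here means a stronger effect of the compound at the dose given, a lower number a weaker effect. In this assay compound 1 gives 21.4%, compound 2 gives 33.8% and compound 3 gives 46.1%. The shift hydrogen in place of methyl on a saturated chain carbon bound to a nitrogen on an aromatic ring changed the read-out by a number 12.4 percentage points lower from compound 2 to compound 1 (beyond the scatter). How the core of compound 3 differs from that of compound 2 is not broken down here.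

Compound 4 `CCNC(=S)NNC(=O)Cn1c(=O)oc2ccc(C)cc21` remains to be measured in this assay. It differs from compound 3 by hydrogen in place of methyl on a saturated chain carbon, two bonds along the chain from an amide-type nitrogen. This is the same kind of change as that from compound 2 to compound 1, though the place is not the same: there the carbon is bound to a nitrogen on an aromatic ring, here it is two bonds along the chain from an amide-type nitrogen. A step of similar size and direction is expected, a number 11.1 percentage points lower from compound 3 to compound 4 (beyond the scatter), resting on compound 2 to compound 1 giving a number 12.4 percentage points lower from compound 2 to compound 1 (beyond the scatter). Compound 4 is therefore estimated at 35%, within 22% to 48%.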

Compound 4, a percentage reported as inhibition, in the whole organism at one dose (the size of the read-out at that dose, not a potency): 36.3%
Compound 4: the middle estimate sits 1.3 percentage points below what was measured, within the range that was stated.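

In this assay, propyl to ethyl on the chain gives a number 9.8 percentage points lower from compound 3 to compound 4 (within the scatter). Set beside the same change on the other core, the two steps do not differ beyond what repeated measurement would allow: the same change on two cores in this assay, a number 12.4 percentage points lower (beyond the scatter) from compound 2 to compound 1 and a number 9.8 percentage points lower (within the scatter) from compound 3 to compound 4, 2.6 percentage points apart, within the scatter of two such steps This shows that the change carried over between these two cores without a detectable difference, but it rests on one pair per core, and the step on the core of compound 3 stays within the scatter, so it sets no rule for other cores or other chains.

The compounds shown leave open how a longer chain such as butyl, or a branched chain such as isopropyl, would read on either core. They also leave open whether a cyclohexyl ring in that place would follow the same course.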